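This account rests on a few compounds, and the source may have more. Where it says the series, first, only, none or still open, it means among the compounds named here.

Compound 1 `O=C(CSc1nnc(-c2ccncc2)n1-c1ccccc1)N/N=C/c1ccccc1`: 23600 nM
Compound 2 `O=C(CSc1nnc(-c2ccncc2)n1-c1ccccc1)N/N=C/c1ccc(Cl)cc1`: 9930 nM

In a functional assay on MCF7 cells (Homo sapiens) for inhibition, read by MTT assay, with a stated time of 48 h (a lower number here means a stronger inhibitor, a higher number a weaker inhibitor), compound 1 gives 23600 nM and compound 2 gives 9930 nM. For the measured compounds named here, of these two numbers, compound 2 has the lower one; the only other measured compound is compound 1, and the single measured step, a 2.4-fold lower number from compound 1 to compound 2 (0.38 log units; beyond the scatter), separates them. That step is the replacement of hydrogen by chloro on an aromatic carbon.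

Compound 3 `O=C(CSc1nnc(-c2ccncc2)n1-c1ccccc1)N/N=C/c1ccc(F)cc1` has not yet been measured. It differs from compound 2 in one place: fluoro in place of chloro on an aromatic carbon. Going by the values given here, the only measured step that bears on this is a 2.4-fold lower number from compound 1 to compound 2 (0.38 log units; beyond the scatter), which shows what a chloro on this aromatic carbon did compared with hydrogen. Among the compounds with values here, no measured compound here carries fluoro, so the new group is untested. Since the measured pair shows hydrogen on one side and chloro on the other, a small move back toward the number of compound 1 seems the most likely outcome, though not one expected to exceed the scatter. In this assay compound 3 is expected to give 15000 nM, with a range from 7000 nM to 35000 nM. That estimate means an expected step of a 1.5-fold higher number from compound 2 to compound 3 (0.18 log units; within the scatter).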

Compound 3, half-maximal inhibitory concentration: 12300 nM
For compound 3 the middle estimate is 1.2-fold (0.09 log units) above the measured one, and the stated range covers the measured number.
By their numbers in this assay, from the lowest: compounds 2, 3 and 1 (each within the scatter of the next, the first and the last beyond it).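

Replacing chloro with fluoro on this aromatic carbon gives a 1.2-fold higher number from compound 2 to compound 3 (0.09 log units; within the scatter) in this assay, so the two halogens cannot be told apart at this position in this cell assay. The second comparison adds a limit to what the earlier chloro result showed: fluoro in place of hydrogen gives a 1.9-fold lower number from compound 1 to compound 3 (0.28 log units; within the scatter), whereas chloro in place of hydrogen gave a 2.4-fold lower number from compound 1 to compound 2 (0.38 log units; beyond the scatter), so only the chloro step clears the usual variation between repeated measurements, and the fluoro compound cannot be separated from either neighbour. No measured evidence is available here to explain these small differences.

From the compounds shown here alone, it remains open whether a group other than a halogen on this aromatic carbon, such as a methoxy group, an amine or a carboxylic acid, would change the number by more than these halogen swaps do. All three compounds also share the same core, so these comparisons leave open whether chloro and fluoro would again read alike if another part of the molecule were changed.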